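This account rests on a few compounds, and the source may have more. Where it says the series, first, only, none or still open, it means among the compounds named here.

Compound 2 `Cc1ccc(S/C(=C/c2ccc(Br)cc2)C(=O)c2ccc(Cl)cc2)cc1` carries a 4-methylphenyl on a sulfur. In a functional assay on DU-145 cells (Homo sapiens) for inhibition, read by trypan blue exclusion, with a stated time of 96 h (on this read-out higher numbers stand for weaker inhibition of growth and lower numbers for stronger inhibition of growth), compound 2 gives 25000 nM. Compound 1 `Cc1ccc(S(=O)(=O)/C(=C/c2sccc2C)C(=O)c2ccc(Br)cc2)cc1` gives 25000 nM, the same number at the digits printed, and the two stand together as the highest of the three measured values; compound 3 `O=C(/C(=C\c1ccc(Br)cc1)SCc1ccc(Cl)cc1)c1ccc(Cl)cc1` gives 1000 nM. Among the compounds with values here, the only single change measured here is a 25-fold lower number from compound 2 to compound 3 (1.40 log units; beyond the scatter), which alters the group on a sulfur and not the position that changes next.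

Compound 4 `Cc1ccc(S/C(=C/c2c[nH]c3ccccc23)C(=O)c2ccc(Cl)cc2)cc1` differs from compound 2 at a double-bonded chain carbon bound to a double-bonded chain carbon: 1H-indol-3-yl in place of 4-bromophenyl on a double-bonded chain carbon bound to a double-bonded chain carbon. Within the data shown here, no measured step alters this position, so the size and direction of the step cannot be read from the data; compound 1 and compound 2 differ in several places at once and show only that those differences left the number unchanged at the digits printed. The step from compound 2 to compound 4 is therefore expected to be small, a 1.7-fold lower number from compound 2 to compound 4 (0.22 log units; within the scatter). Compound 4 is estimated at 15000 nM, with a range from 4000 nM to 50000 nM.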

Compound 4, concentration for 50% growth inhibition: 10000 nM
The estimate for compound 4 lay 1.5-fold (0.18 log units) above the measured number; the measured number falls inside the stated range.
By their numbers in this assay, from the lowest: compound 3; then compound 4; then compounds 1 and 2 (each within the scatter of the next).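

Within the data shown here, this is the first reading of the position on a double-bonded chain carbon bound to a double-bonded chain carbon: 1H-indol-3-yl in place of 4-bromophenyl gives a 2.5-fold lower number from compound 2 to compound 4 (0.40 log units; beyond the scatter) in this assay and so shows that the number responds to the group placed here. Among these compounds, the single swap removes the bromine and brings in a five-membered aromatic ring and a hydrogen-bond donor together, so these parts cannot be told apart from this one step. No measurement at hand speaks to the reason for the step.

Open, going by these compounds, is how a simple phenyl, a 4-methoxyphenyl or a 4-aminophenyl would read on this same carbon. Also open, on these data alone, is whether 1H-indol-3-yl would give a similar step with the 4-chlorobenzyl of compound 3 on the sulfur.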